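Phenyl for tert-butyl at the methyl position of the core

A few compounds are considered here, and "the series" means these few. Any claim that something is new, unique, unknown or untested is made for them only; others in the source may bear on it.

Measured compounds:
compound 1 `COCCNc1nc(C)cc2nn(-c3ccccc3)c(N)c12` in an assay on isolated protein for inhibition of MAP kinase-activated protein kinase 5 (Homo sapiens), read by mobility shift assay, tested at 30 uM; a lower number here means less inhibition, a higher number more inhibition at the concentration tested (going by the name of the read-out): 2%
compound 2 `Cc1cc2nn(-c3ccccc3)c(N)c2c(=O)[nH]1` in this assay: 5%
compound 3 `CC(C)(C)c1cc2nn(-c3ccccc3)c(N)c2c(=O)[nH]1` in this assay: 2%

Compound 3 stands level with compound 1 at the digits printed, and the two together are the lowest of the three numbers; compound 2 is the furthest from compound 3, and that gap is within the scatter. Within the data shown here, the one measured step that changes the same position as the step now in question is a number 3 percentage points lower from compound 2 to compound 3 (within the scatter), a within-scatter change for tert-butyl in place of methyl on an aromatic carbon. Compound 1, with a different core, gives the same number as compound 3, so the whole set so far sits at the bottom of the scale.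

Compound 4 `Nc1c2c(=O)[nH]c(-c3ccccc3)cc2nn1-c1ccccc1` differs from compound 3 as follows. phenyl in place of tert-butyl on an aromatic carbon

Among the measured compounds shown here, the only step that bears on it, from compound 2 to compound 3, was within the scatter, and no other substituent at this position has been measured. A change beyond the scatter is therefore not expected in this assay, in either direction. For compound 4 the estimate is 4%, with a range from 0% to 14%, which means an expected step of a number 2 percentage points higher from compound 3 to compound 4 (within the scatter).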

Compound 4, a percentage reported as inhibition, at one concentration (the size of the read-out at that concentration, not a potency): 22%
Compound 4: the middle estimate sits 18 percentage points below what was measured; measured number above the stated range.
By their numbers in this assay, from the lowest: compounds 1, 3 and 2 (each within the scatter of the next); then compound 4.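

In this assay, among these compounds, this position on the shared core turns out to respond to the group placed there: phenyl in place of tert-butyl gives a number 20 percentage points higher from compound 3 to compound 4 (beyond the scatter), and phenyl in place of methyl gives a number 17 percentage points higher from compound 2 to compound 4 (beyond the scatter), whereas the one earlier step at this position, a number 3 percentage points lower from compound 2 to compound 3 (within the scatter), showed no change beyond the scatter. Methyl and tert-butyl therefore cannot be told apart here, while phenyl separates from both, although the read-out remains a modest inhibition at a single concentration and gives no potency. Nothing at hand bears on why phenyl behaves differently from the two other groups.

Still open, from the compounds shown here alone, is whether the rise depends on the aromatic ring itself, which a cyclohexyl group at this position would test, or on a ring of carbon only, which a pyridyl group would test. Also open, going by these compounds, is whether a substituent on the new phenyl, such as a methoxy group or a chlorine, would move the number further, and whether a benzyl group, with a carbon linking the ring to the core, would keep the rise.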